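The source may hold more compounds than are shown below. What is called first, only, known or untested is meant among the compounds shown, and "the series" means these compounds.

Of the compounds shown here, three on a shared core have so far been tested in a functional assay on A549 cells (Homo sapiens) for cytotoxicity, read by MTT assay, with a stated time of 72 h; on this read-out higher numbers stand for weaker inhibition and lower numbers for stronger inhibition. Compound 1 `Cc1cc(=O)n(-c2ccc(Br)cc2F)nc1C(=O)Nc1ccc(Oc2ncnc3c2ccn3C)cc1` gives 47300 nM in this assay. Compound 2 `Cc1cc(=O)n(-c2cccc(F)c2)nc1C(=O)Nc1ccc(Oc2ncnc3c2ccn3C)cc1` carries 3-fluorophenyl in place of 4-bromo-2-fluorophenyl on an aromatic nitrogen; in this assay compound 2 gives 23400 nM, which amounts to a 2.0-fold lower number from compound 1 to compound 2 (0.31 log units; beyond the scatter). Compound 3 `Cc1cc(=O)n(-c2ccc(Br)cc2F)nc1C(=O)Nc1ccc(Oc2ncnc3c2ccn3C)c(F)c1` differs from compound 1 by fluoro in place of hydrogen on an aromatic carbon; in this assay compound 3 gives 14400 nM, which amounts to a 3.3-fold lower number from compound 1 to compound 3 (0.52 log units; beyond the scatter). Compound 4 `Cc1cc(=O)n(-c2cccc(F)c2)nc1C(=O)Nc1ccc(Oc2ncnc3c2ccn3C)c(F)c1` has not yet been measured. Going by the values given here, it differs from compound 3 by 3-fluorophenyl in place of 4-bromo-2-fluorophenyl on an aromatic nitrogen, the same change at the same place as the one separating compound 1 from compound 2, now made on the core of compound 3 instead. The earlier occurrence of this change gave a 2.0-fold lower number from compound 1 to compound 2 (0.31 log units; beyond the scatter). The step to compound 4 is therefore expected to be a 2.0-fold lower number from compound 3 to compound 4 (0.30 log units; within the scatter), because the same change once gave a 2.0-fold lower number from compound 1 to compound 2 (0.31 log units; beyond the scatter). On that basis compound 4 is estimated at 7200 nM in this assay, with most repeat measurements expected to fall between 3500 nM and 15000 nM.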

Compound 4, half-maximal inhibitory concentration: > 60000 nM
Compound 4 was reported as a limit; the forecaster's own chance of this, stated with the estimate: 5%; middle value at least 8.3-fold (0.92 log units) from the limit.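

In this assay compound 4 gives > 60000 nM, which is a limit of the assay and not a number. Placing 3-fluorophenyl in place of 4-bromo-2-fluorophenyl on the aromatic nitrogen now gives an at least 4.1-fold higher number from compound 3 to compound 4 (0.61 log units; beyond the scatter), so this change did not carry from one core to the other: the same change on two cores in this assay, a 2.0-fold lower number (0.31 log units; beyond the scatter) from compound 1 to compound 2 and an at least 4.1-fold higher number (0.61 log units; beyond the scatter) from compound 3 to compound 4, at least 8.4-fold (0.92 log units) apart, beyond the scatter of two such steps The fluoro in place of hydrogen on an aromatic carbon likewise reverses direction, giving an at least 2.5-fold higher number from compound 2 to compound 4 (0.40 log units; beyond the scatter), so the two changes do not simply add on this shared core, though this single set of compounds shows neither how far compound 4 lies beyond its limit nor why the steps reverse: the same change on two cores in this assay, a 3.3-fold lower number (0.52 log units; beyond the scatter) from compound 1 to compound 3 and an at least 2.5-fold higher number (0.40 log units; beyond the scatter) from compound 2 to compound 4, at least 8.4-fold (0.92 log units) apart, beyond the scatter of two such steps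

The compounds shown leave open whether such a reversal would also appear with other groups on the aromatic nitrogen, such as an unsubstituted phenyl or a chlorophenyl. They also leave open how chloro or methoxy in place of the fluoro on the aromatic carbon would behave alongside each of these groups.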